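This account rests on a few compounds, and the source may have more. Where it says the series, first, only, none or still open, it means among the compounds named here.

Compound 1 (`O=C(c1ccc(C#Cc2ccc(Oc3ccccc3)cc2)cc1)N1CCC[C@@H](CO)C1`) is an aryl ether carrying a hydroxymethylpiperidine amide. In a functional assay on TREX cells for negative allosteric modulation of metabotropic glutamate receptor 3 (Rattus norvegicus), read by calcium flux, with a stated time of 2.5 min (a lower number here means a stronger inhibitor, a higher number a weaker inhibitor), compound 1 gives only a limit, > 10000 nM, and not a number. That limit is the one described by the limit of > 10000 nM in this assay, at which 1 of the 3 values shown sits. Compound 4 (`CCOc1ccc(C#Cc2ccc(C(=O)N3CCC[C@@H](CO)C3)cc2)cc1`) keeps the whole shared core and amide, and differs only in that (ethyl in place of phenyl on an oxygen on an aromatic ring). Within the data shown here, no measured pair shows this exact exchange. Two other compounds carry a methoxy on the outer aromatic ring instead: compound 2 (`COc1ccc(C#Cc2ccc(C(=O)N3CCCC(OC)C3)cc2)cc1`) gives 5500 nM in this assay, and compound 3 (`COc1ccc(C#Cc2ccc(C(=O)N3CC[C@@H](O)C3)cc2)cc1`) gives 10200 nM. Among the measured compounds shown here, the one measured step, a 1.9-fold higher number from compound 2 to compound 3 (0.27 log units; within the scatter), changes the amide side and not the ether, so it says nothing about the ethyl for phenyl exchange itself; it only shows that such small-alkoxy compounds give numbers near the upper end of the measured range. Compound 4 is therefore expected to give about 8000 nM, likely between 3000 nM and 20000 nM. That estimate means an expected step of an at least 1.2-fold lower number from compound 1 to compound 4 (0.09 log units; that floor lies within the scatter).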

Compound 4, half-maximal inhibitory concentration: > 10000 nM
Compound 4: a limit, no number; the forecaster's own chance of this, stated with the estimate: 40%; middle value at least 1.2-fold (0.09 log units) away from the limit.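

Among these compounds, compound 1 and compound 4 each give only a limit in this assay, not a number, so no step between them can be read: the limit of > 10000 nM in this assay, at which 2 of the 4 values shown sit. The compounds shown leave open whether the exchange of phenoxy for ethoxy changes the strength of inhibition at all.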